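A few compounds are considered here, and "the series" means these few. Any claim that something is new, unique, unknown or untested is made for them only; others in the source may bear on it.

Measured compounds in an ADME assay on MT4 cells (Homo sapiens) for cytotoxicity, read by MTT assay; on this read-out lower numbers stand for higher toxicity in this test and higher numbers for lower toxicity in this test:
Compound 1, `NS(=O)(=O)c1ccc(NC(=O)CSc2ncncc2-c2cccc3ccccc23)c(Br)c1`, gives 24100 nM.
Compound 2, `CCOC(=O)c1ccc(NC(=O)CSc2ncncc2-c2cccc3ccccc23)c(Br)c1`, gives 211000 nM.
Compound 3, `CCOC(=O)c1ccc(NC(=O)CSc2ncncc2-c2cccc3ccccc23)c(Cl)c1`, gives 195000 nM.

Among these three numbers compound 3 stands second highest. Its value and that of compound 2 lie within the scatter of each other, so no order can be read between them, whereas compound 1 gives a number far lower than compound 3.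

Compound 4, `CONC(=O)c1ccc(NC(=O)CSc2ncncc2-c2cccc3ccccc23)c(Cl)c1`, is not yet measured. It differs from compound 3 in one place: methoxyamino in place of ethoxy on a carbonyl carbon. The change sits on the carbonyl carbon whose other neighbour is an aromatic carbon.

Two measured steps exist. The step of a 1.1-fold lower number from compound 2 to compound 3 (0.03 log units; within the scatter) exchanged the halogen and stayed within the scatter. Among the measured compounds shown here, the step of an 8.8-fold higher number from compound 1 to compound 2 (0.94 log units; beyond the scatter) exchanged the group on that same carbonyl-bearing carbon and moved the number beyond the scatter; it is the only step that touches the part now altered, though it swaps different groups. For the measured compounds named here, no step exchanges ethoxy for methoxyamino directly, so the expectation rests on the one finding that changing this group can shift the number, and the direction is uncertain. A modest lowering is expected as the step of a 1.5-fold lower number from compound 3 to compound 4 (0.18 log units; within the scatter), with a wide range around it. Compound 4 is therefore estimated at about 130000 nM, with the likely span running from 45000 nM to 350000 nM.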

Compound 4, half-maximal cytotoxic concentration: 131000 nM
The estimate for compound 4 lay 1.0-fold (0.00 log units) below the measured number; the range from low to high includes it.
By their numbers in this assay, from the lowest: compound 1; then compounds 4, 3 and 2 (each within the scatter of the next).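

In this assay, putting methoxyamino in place of ethoxy on the carbonyl carbon gives a 1.5-fold lower number from compound 3 to compound 4 (0.17 log units; within the scatter), even though methoxyamino carries a hydrogen-bond donor that ethoxy lacks. Among the compounds shown here, the earlier compounds showed only that a larger exchange at this part of the molecule, ethoxycarbonyl in place of sulfamoyl, can give an 8.8-fold higher number from compound 1 to compound 2 (0.94 log units; beyond the scatter); the new result shows that not every change here moves the number beyond the scatter. Nothing available explains why this change stays within the scatter.

The compounds shown leave open whether a carboxylic acid, a plain amine or a longer chain on this carbonyl carbon would also stay within the scatter. They also leave open whether methoxyamino would act the same way with bromo in place of chloro on the aromatic carbon.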